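Aryl sulfonate imidazolidinones: methoxy additions on the phenoxy ring

This account rests on a few compounds, and the source may have more. Where it says the series, first, only, none or still open, it means among the compounds named here.

Measured in a functional assay on HT-29 cells (Homo sapiens) for antiproliferative activity, read by sulforhodamine B assay, with a stated time of 48 h; a higher number here means a weaker inhibitor, a lower number a stronger inhibitor:
compound 1, `COc1cc(OC)cc(OS(=O)(=O)c2ccc(N3CCN(C)C3=O)cc2)c1`, gives 190 nM.
compound 2, `COc1cc(OS(=O)(=O)c2ccc(N3CCN(C)C3=O)cc2)cc(OC)c1OC`, gives 62 nM.
compound 3, `CCCCN1CCN(c2ccc(S(=O)(=O)Oc3ccccc3)cc2)C1=O`, gives > 100000 nM, which is a limit of this assay and not a number.

From compound 1 to compound 2 the change is methoxy in place of hydrogen on an aromatic carbon, and it brings a 3.1-fold lower number from compound 1 to compound 2 (0.49 log units; beyond the scatter). The same kind of change leads from compound 3 to compound 4, `CCCCN1CCN(c2ccc(S(=O)(=O)Oc3ccccc3OC)cc2)C1=O`: methoxy in place of hydrogen on an aromatic carbon. The surroundings differ, though: in compound 2 the entering methoxy is ortho to two methoxy groups and para to a large group, whereas in compound 4 it is ortho to a large group only. How the core of compound 3 differs from that of compound 1 is not broken down here. Compound 3 stands at the limit of > 100000 nM in this assay, at which 1 of the 3 values shown sits. A step of the earlier size from there would still leave compound 4 weak. Compound 4 is therefore expected near 100000 nM, between 30000 nM and 300000 nM. The expected step is a number no higher from compound 3 to compound 4 (the limit leaves the size open), and a limit result remains the likelier outcome.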

Compound 4, half-maximal inhibitory concentration: > 100000 nM
Compound 4: a limit, no number (the forecaster's own chance of this, stated with the estimate: 70%); the middle value sits exactly at the limit.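

Among these compounds, compound 3 and compound 4 both give only a limit, not a number, in this assay, so no step between them can be read. The compounds shown leave open whether methoxy in place of hydrogen changes activity at all on the core of compound 3.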